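The compounds below may be only part of what the source reports. "The series", "measured", "known", "first", "only" and "open" are said of these compounds alone.

Compound 1 `CCCC#Cc1cn([C@@H]2O[C@H](CO)[C@@H](O)[C@H](O)[C@H]2O)c(=O)[nH]c1=O` is tested in a functional assay on HeLa cells (Homo sapiens) for cytotoxicity, with a stated time of 72 h (a higher number here means a weaker inhibitor, a lower number a stronger inhibitor), where compound 1 gives 95000 nM. Among the numbers actually measured, this is the higher of two: compound 3 `O=c1nc(O)c(C#Cc2ccccc2)cn1[C@@H]1O[C@H](CO)[C@@H](O)[C@H](O)[C@H]1O`, which carries a phenyl group on the triple bond, gives 5400 nM in this assay, a gap that lies well beyond the scatter. Compound 2 `CCCCCC#Cc1cn([C@@H]2O[C@H](CO)[C@@H](O)[C@H](O)[C@H]2O)c(=O)nc1N` reaches only a limit of this assay, reported as >= 250000 nM, so it contributes no number to compare (the limit of >= 250000 nM in this assay, at which 1 of the 3 values shown sits).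

Compound 4 `O=c1[nH]c(=O)n([C@@H]2O[C@H](CO)[C@@H](O)[C@H](O)[C@H]2O)cc1C#Cc1ccccn1` is not yet measured. It differs from compound 1 in one place: pyridin-2-yl in place of propyl on a triple-bonded carbon. This makes compound 4 an aryl alkyne like compound 3 rather than an alkyl alkyne like compound 1, so the step from compound 1 to compound 4 is expected to go toward a lower number, of a size comparable to the gap between the values of compound 1 and compound 3 rather than within the scatter, giving a 9.5-fold lower number from compound 1 to compound 4 (0.98 log units; beyond the scatter). Compound 4 is therefore estimated at 10000 nM in this assay, with a likely range from 3000 nM to 40000 nM.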

Compound 4, half-maximal inhibitory concentration: 66000 nM
For compound 4 the middle estimate is 6.6-fold (0.82 log units) below the measured one, outside the stated range (above it).
By their numbers in this assay, from the lowest: compound 3; then compounds 4 and 1 (each within the scatter of the next). At a limit, above all of these: compound 2.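

In this assay the step is a 1.4-fold lower number from compound 1 to compound 4 (0.16 log units; within the scatter) when pyridin-2-yl takes the place of propyl on a triple-bonded carbon, so at this place the ring and the open chain cannot be told apart. An aromatic ring on the triple bond is therefore not enough in itself, since compound 3 gives 5400 nM with phenyl at this place, while compound 4 stays with compound 1. Nothing measured here accounts for this outcome.

The compounds shown leave open whether other rings at this place, such as pyridin-3-yl or pyridin-4-yl, would give numbers closer to compound 3 or to compound 4. They also leave open what an amine or a carboxylic acid on the end of the triple bond would do.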